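The source may hold more compounds than are shown below. What is called first, only, known or untested is meant among the compounds shown, and "the series" means these compounds.

Working notes on the series

Compound 1 `CNc1nc(-c2cc(OC)c(OC)c(OC)c2)c(-c2ccc(OC)cc2)s1` is the reference. In a functional assay on HeLa cells (Homo sapiens) for antiproliferative activity, read by MTT assay, with a stated time of 72 h (a higher number here means a weaker inhibitor, a lower number a stronger inhibitor), compound 1 gives 70.1 nM. Compound 2 `CCOc1ccc(-c2sc(NC)nc2-c2cc(OC)c(OC)c(OC)c2)cc1` carries methyl in place of hydrogen on a saturated chain carbon bound to an oxygen on an aromatic ring and in this assay compound 2 gives 13.2 nM, a change of a 5.3-fold lower number from compound 1 to compound 2 (0.73 log units; beyond the scatter). Compound 3 `COc1ccc(-c2sc(N(C)C)nc2-c2cc(OC)c(OC)c(OC)c2)cc1` differs from compound 1 by methyl in place of hydrogen on a nitrogen on an aromatic ring; in this assay compound 3 gives 3370 nM, a change of a 48-fold higher number from compound 1 to compound 3 (1.68 log units; beyond the scatter), leaving compound 3 as the weakest of the three measured.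

Compound 4 `CCOc1ccc(-c2sc(N(C)C)nc2-c2cc(OC)c(OC)c(OC)c2)cc1` is not yet measured. It differs from compound 3 by methyl in place of hydrogen on a saturated chain carbon bound to an oxygen on an aromatic ring, the same change that separates compound 2 from compound 1, at the same place. Going by the values given here, on the core of compound 3 the step from compound 3 to compound 4 in this assay is expected to resemble the earlier one, a 4.5-fold lower number from compound 3 to compound 4 (0.65 log units; beyond the scatter), resting on the single precedent of compound 1 to compound 2 a 5.3-fold lower number from compound 1 to compound 2 (0.73 log units; beyond the scatter); with one example it may not carry over fully onto the weaker core. The estimate for compound 4 in this assay is therefore 750 nM, expected between 250 nM and 2200 nM.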

Compound 4, half-maximal inhibitory concentration: 3260 nM
Compound 4: middle estimate off by 4.3-fold (0.64 log units), on the low side; measured number above the stated range.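

In this assay the change from 4-methoxyphenyl to 4-ethoxyphenyl does not carry over from the core of compound 1 to the core of compound 3, where the step reads a 1.0-fold lower number from compound 3 to compound 4 (0.01 log units; within the scatter), and the two steps differ by more than the scatter: the same change on two cores in this assay, a 5.3-fold lower number (0.73 log units; beyond the scatter) from compound 1 to compound 2 and a 1.0-fold lower number (0.01 log units; within the scatter) from compound 3 to compound 4, 5.1-fold (0.71 log units) apart, beyond the scatter of two such steps

Read the other way, methyl in place of hydrogen on a nitrogen on an aromatic ring gives a 250-fold higher number from compound 2 to compound 4 (2.39 log units; beyond the scatter), so that change also depends on its partner group: the same change on two cores in this assay, a 48-fold higher number (1.68 log units; beyond the scatter) from compound 1 to compound 3 and a 250-fold higher number (2.39 log units; beyond the scatter) from compound 2 to compound 4, 5.1-fold (0.71 log units) apart, beyond the scatter of two such steps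

These four compounds form a single square, which shows that the two changes do not add up independently here; it does not show that the ethoxy gain disappears on every weaker core, and it gives no cause for the difference.

As far as these compounds go, it remains open whether a longer chain, such as propoxy, would give any step on the core of compound 3. From the compounds shown here alone, it is also open whether ethyl or cyclopropyl on that nitrogen would behave as the added methyl does, and whether the pattern holds in other cell lines.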